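Methoxy to phenoxy in a series at its limit

The compounds below may be only part of what the source reports. "The series", "measured", "known", "first", "only" and "open" are said of these compounds alone.

- compound 1 `CCOC(=O)c1c(-c2cccc(Oc3ccccc3)c2)[nH]c2cc(Cl)c(Cl)cc2c1=O`: > 22000 nM
- compound 2 `CCOC(=O)c1c(-c2cccc(OC)c2)[nH]c2cc(OC)c(Cl)cc2c1=O`: > 22000 nM

In an ADME assay on HEK293 cells (Homo sapiens) for cytotoxicity, read by luminescence, with a stated time of 72 h (a higher number here means that more compound is needed for the effect, a lower number that less compound is needed), compound 2 gives > 22000 nM, which is a limit of the assay and not a number. The two measured compounds share one position: the limit of > 22000 nM in this assay, at which 2 of the 2 values shown sit. Going by the values given here, no step between measured compounds is available, so neither size nor direction can be read from the data directly.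

Compound 3 `CCOC(=O)c1c(-c2cccc(Oc3ccccc3)c2)[nH]c2cc(OC)c(Cl)cc2c1=O` has phenyl in place of methyl on an oxygen on an aromatic ring, methoxy to phenoxy (phenyl in place of methyl on an oxygen on an aromatic ring). Compound 1 also carries phenoxy and gives > 22000 nM, again a limit. On that basis, no change beyond the usual scatter is expected in this assay, in either direction, and a further limit is the likeliest report. The expected size of the change is a number no higher from compound 2 to compound 3 (the limit leaves the size open). For compound 3 the estimated value is 22000 nM, with an expected range of 12000 nM to 30000 nM.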

Compound 3, half-maximal effective concentration: > 22000 nM
Compound 3: a limit, no number; the forecaster's own chance of this, stated with the estimate: 85%; the middle value sits exactly at the limit.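

In this assay, going by these compounds alone, compound 3 gives > 22000 nM, a limit of the assay and not a number, so no step from it to compound 1 or compound 2 can be read. The compounds shown leave open whether methoxy to phenoxy, or methoxy in place of chloro, changes the half-maximal effective concentration at all.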